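This account rests on a few compounds, and the source may have more. Where it says the series, first, only, none or still open, it means among the compounds named here.

In an assay on isolated protein for inhibition of DNA topoisomerase 1 (Homo sapiens), with a stated time of 30 min, tested at 100 uM (on this read-out lower numbers stand for a weaker effect and higher numbers for a stronger effect at the one concentration tested), compound 3 `Oc1ccc(-c2cc(-c3ccncc3)nc(-c3cccc(Cl)c3)c2)cc1` gives 29.2%, the highest of the three numbers recorded so far. In this assay compound 2 `Oc1cccc(-c2cc(-c3cccc(Cl)c3)nc(-c3ccco3)c2)c1` gives 5.5%, and compound 1 `Oc1ccc(-c2cc(-c3ccco3)nc(-c3ccccc3Cl)c2)cc1` gives 3.9%; each of these two readings lies beyond the scatter below that of compound 3.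

Compound 4 `Oc1ccc(-c2cc(-c3cccc(Cl)c3)nc(-c3ccco3)c2)cc1` has not yet been measured. It differs from compound 3 in a single place: furan-2-yl in place of pyridin-4-yl on an aromatic carbon. Among the measured compounds shown here, no measured pair isolates exactly this exchange, so the expectation leans on the neighbours that already carry a furan-2-yl group. Compounds 1 and 2 both carry that group, and both sit far below compound 3 in this assay, which points to a loss of inhibition when the pyridin-4-yl of compound 3 is given up. Compound 4 is therefore expected to fall, with a number 21.2 percentage points lower from compound 3 to compound 4 (beyond the scatter) taken as a drop beyond the scatter, because compound 2 gives 5.5% with the same two remaining groups. The estimate for compound 4 is 8%, in a range from 0% to 25%.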

Compound 4, a percentage reported as inhibition, at one concentration (the size of the read-out at that concentration, not a potency): 25.5%
Estimate against measurement, compound 4: 17.5 percentage points below; measured number above the stated range.
By their numbers in this assay, from the lowest: compounds 1 and 2 (each within the scatter of the next); then compounds 4 and 3 (each within the scatter of the next).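

In this assay, the exchange of pyridin-4-yl for furan-2-yl next to the ring nitrogen gives a number 3.7 percentage points lower from compound 3 to compound 4 (within the scatter) and so costs no measurable inhibition; the furan-2-yl group alone therefore does not account for the low readings of compound 1 and compound 2. With furan-2-yl kept in place, the two aryl groups make the difference: 4-hydroxyphenyl in place of 3-hydroxyphenyl gives a number 20 percentage points higher from compound 2 to compound 4 (beyond the scatter) and 3-chlorophenyl in place of 2-chlorophenyl gives a number 21.6 percentage points higher from compound 1 to compound 4 (beyond the scatter) in the same test. Alongside the 3-chlorophenyl and 4-hydroxyphenyl groups, this position thus accepts either ring.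

From the compounds shown here alone, whether a saturated amine such as piperidin-4-yl, or a plain phenyl ring, would hold the reading at this position remains open. No available evidence explains these steps.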